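The source may report more compounds than this note shows. Statements on the series, on what has been measured and on what is new or still open speak of the compounds shown alone.

Three compounds have so far been measured in a functional assay on MCF7 cells (Homo sapiens) for antiproliferative activity, read by MTT assay, with a stated time of 72 h; on this read-out higher numbers stand for weaker inhibition and lower numbers for stronger inhibition:

- compound 1 `C/C=C/C(=O)Nc1cc2c(N3CCc4ccccc43)ncnc2cc1OC`: 4030 nM
- compound 2 `CC/C=C/C(=O)Nc1cc2c(N3CCc4ccccc43)ncnc2cc1OC`: 4030 nM
- compound 3 `C/C=C/C(=O)Nc1cc2c(N3CCCc4ccccc43)ncnc2cc1O[C@@H]1CCOC1`: 5930 nM

Compound 1 and compound 2 share one core and differ in a single place: methyl in place of hydrogen on a saturated chain carbon bound to a double-bonded chain carbon. This change made the step of no change at the digits printed from compound 1 to compound 2 (within the scatter), so lengthening the unsaturated amide chain by one carbon left the result in this assay essentially where it was.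

Compound 3 carries a different core from compound 1, and the difference between the two cores is not broken down here. Its value in this assay sits close to those of compound 1 and compound 2, and the gaps among the three fall within the usual scatter, so no order among them can be read.

Compound 4 `CC/C=C/C(=O)Nc1cc2c(N3CCCc4ccccc43)ncnc2cc1O[C@@H]1CCOC1` is the companion to compound 3 that remains to be measured. It differs from compound 3 by methyl in place of hydrogen on a saturated chain carbon bound to a double-bonded chain carbon, the same change that separates compound 2 from compound 1, at the same place. Because the earlier step of no change at the digits printed from compound 1 to compound 2 (within the scatter) was flat, the step from compound 3 to compound 4 is also expected to be small, about a 1.0-fold lower number from compound 3 to compound 4 (0.00 log units; within the scatter). On that basis compound 4 is estimated to give 5900 nM in this assay, expected to fall between 3000 nM and 12000 nM.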

Compound 4, half-maximal inhibitory concentration: 14400 nM
The estimate for compound 4 lay 2.4-fold (0.39 log units) below the measured number; measured number above the stated range.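

In this assay, methyl in place of hydrogen on a saturated chain carbon bound to a double-bonded chain carbon gave a 2.4-fold higher number from compound 3 to compound 4 (0.39 log units; beyond the scatter), a modest step towards weaker inhibition on the core of compound 3. Set beside the earlier step on the core of compound 1, this step cannot be called a different outcome, as the gap between the two stays small enough to be ordinary scatter: the same change on two cores in this assay, no change at the digits printed (within the scatter) from compound 1 to compound 2 and a 2.4-fold higher number (0.39 log units; beyond the scatter) from compound 3 to compound 4, 2.4-fold (0.39 log units) apart, within the scatter of two such steps. So the change carries from one core to the other without a demonstrable difference, but this does not prove that the two cores respond alike, since only one pair per core is available and one of the two steps is flat while the other goes beyond the scatter.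

Going by these compounds, with two pairs, it remains open whether the step on the core of compound 3 would recur on further cores or is specific to that core. On these data alone, it also remains open how this assay would respond to a longer chain in place of but-1-en-1-yl, or to an amine such as dimethylamino carried at the end of that chain.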